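The compounds below may be only part of what the source reports. "The series", "measured", "known", "first", "only" and "open" are said of these compounds alone.

Measured so far in a functional assay on SW-620 cells (Homo sapiens) for antiproliferative activity, read by sulforhodamine B assay, with a stated time of 48 h; a higher number here means a weaker inhibitor, a lower number a stronger inhibitor:
- compound 1 `O=C(CCCCCCN1C(=O)/C(=N\O)c2cc(F)ccc21)NO`: 110 nM
- compound 2 `O=C(CCCCCCN1C(=O)/C(=N\O)c2cc(Cl)ccc21)NO`: 650 nM
- compound 3 `CO/N=C1/C(=O)N(CCCCCCC(=O)NO)c2ccccc21`: 730 nM

Compound 3, at 730 nM, lies within the scatter of compound 2. Both of these numbers are higher than that of compound 1, and the gap from compound 3 to compound 1 is beyond the scatter.

The next compound is compound 4 `CO/N=C1/C(=O)N(CCCCCCC(=O)NO)c2ccc(C)cc21`, which has methyl in place of hydrogen on an aromatic carbon of compound 3: methyl in place of hydrogen on an aromatic carbon.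

Among the compounds with values here, only one measured step bears on this change, and only indirectly. It is a 5.9-fold higher number from compound 1 to compound 2 (0.77 log units; beyond the scatter), a modest step for chloro in place of fluoro on an aromatic carbon. It shows that a swap on the aromatic ring can move the number in this assay. However, compounds 1 and 2 also differ from compound 3 elsewhere, and no measured step has methyl replacing hydrogen. No direction can be taken from it, so no step beyond the scatter is expected, although one of the modest size seen above remains possible.

The expected step is a 1.2-fold lower number from compound 3 to compound 4 (0.09 log units; within the scatter).

For compound 4 the estimated value is 600 nM, with an expected range of 220 nM to 1600 nM.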

Compound 4, half-maximal inhibitory concentration: 1070 nM
Beside the measured number, compound 4's estimate is 1.8-fold (0.25 log units) below it; the range from low to high includes it.
By their numbers in this assay, from the lowest: compound 1; then compounds 2, 3 and 4 (each within the scatter of the next).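

Methyl in place of hydrogen on an aromatic carbon, meta to a fused ring and para to a fused ring, gives the first direct reading of a hydrogen replacement on this ring in this assay, with a 1.5-fold higher number from compound 3 to compound 4 (0.17 log units; within the scatter). Within the data shown here, the only earlier step on the ring, a swap of chloro for fluoro, was a 5.9-fold higher number from compound 1 to compound 2 (0.77 log units; beyond the scatter), whereas here the numbers of the two compounds cannot be told apart, so this one added carbon leaves no readable mark on the result. No measurement at hand accounts for the difference in size between these two steps.

Going by these compounds, whether an amine, a carboxylic acid or a longer alkyl chain on this same carbon would produce a step beyond the scatter stays open. Also open, on these data alone, is how fluoro or chloro would read on the core of compound 3.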